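Amide aryl exchange on the chlorinated benzamide core

The compounds below may be only part of what the source reports. "The series", "measured", "known", "first", "only" and "open" are said of these compounds alone.

Measured so far:
compound 1, `Cc1cc(OC[C@@H]2CN(C)c3ccccc3O2)ccc1C(=O)Nc1ccc(F)c(CC(=O)O)c1`: 1.2 nM
compound 2, `Cc1cc(CC(=O)O)cc(NC(=O)c2ccc(OC[C@@H]3CN(C)c4ccccc4O3)cc2Cl)c1`: 5.4 nM

In a functional assay on CHO cells for antagonist activity at prostaglandin D2 receptor (Mus musculus), read by cAMP accumulation (on this read-out higher numbers stand for weaker inhibition and lower numbers for stronger inhibition), compound 1 gives 1.2 nM, and compound 2 gives 5.4 nM. Compound 2 stands at the higher of the two numbers; its gap to compound 1 lies beyond the usual scatter. For the measured compounds named here, no step between measured compounds that differ in one place is available, so the two values can only be set side by side: compound 1 and compound 2 differ both in the chloro on the core and in the aryl group on the amide nitrogen.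

Compound 3, `CN1C[C@@H](COc2ccc(C(=O)Nc3ccc(F)c(CC(=O)O)c3)c(Cl)c2)Oc2ccccc21`, is not yet measured. It keeps the core of compound 2 with its chloro and changes only the amide-side group: 3-(carboxymethyl)-4-fluorophenyl in place of 3-(carboxymethyl)-5-methylphenyl on an amide-type nitrogen. Going by the values given here, the group that enters is the one carried by compound 1. Because compound 1 reaches 1.2 nM with that same group, a lower number than for compound 2 is expected, a step of a 2.7-fold lower number from compound 2 to compound 3 (0.43 log units; beyond the scatter) of moderate size. For compound 3 the estimate is 2 nM, within a range from 0.7 nM to 6 nM.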

Compound 3, half-maximal inhibitory concentration: 50 nM
Beside the measured number, compound 3's estimate is 25-fold (1.40 log units) below it; measured number above the stated range.
By their numbers in this assay, from the lowest: compound 1; then compound 2; then compound 3.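

On the chloro-bearing core, in this assay the amide-side exchange to 3-(carboxymethyl)-4-fluorophenyl in place of 3-(carboxymethyl)-5-methylphenyl on the amide-type nitrogen gives a 9.3-fold higher number from compound 2 to compound 3 (0.97 log units; beyond the scatter) and so moves towards weaker inhibition, which shows that the low number of compound 1 does not carry over with this group alone. For the compounds shown here, with that amide-side group held constant, chloro in place of methyl on an aromatic carbon gives a 42-fold higher number from compound 1 to compound 3 (1.62 log units; beyond the scatter) as a large step, the first single-place reading of this core substituent. No supporting data bear on the reason for either step.

Going by these compounds, whether 3-(carboxymethyl)-5-methylphenyl also gives the higher or lower number on the methyl-bearing core remains open, so the two steps cannot yet be separated into independent contributions from the amide-side group and the core substituent. Also open, on these data alone, is how a fluoro, a methoxy or a trifluoromethyl in place of the chloro would read with either amide-side group, and whether a longer acid chain such as carboxyethyl in place of carboxymethyl would change the picture.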